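A few compounds are considered here, and "the series" means these few. Any claim that something is new, unique, unknown or untested is made for them only; others in the source may bear on it.

Measured in a functional assay on DU-145 cells (Homo sapiens) for antiproliferative activity, read by sulforhodamine B assay, with a stated time of 48 h (a higher number here means a weaker inhibitor, a lower number a stronger inhibitor), each entry a limit and not a number:
- compound 1 `CCCCN(C)C(=O)CCCOc1cc(OC)c(OC)c2oc(-c3ccc(OC)cc3)c(O)c(=O)c12`: > 40000 nM
- compound 2 `COc1ccc(-c2oc3c(OC)c(OC)cc(OCCCC(=O)NCc4ccccn4)c3c(=O)c2O)cc1`: > 40000 nM
- compound 3 `COc1ccc(-c2oc3c(OC)c(OC)cc(OCCCC(=O)N4CCN(C)CC4)c3c(=O)c2O)cc1`: > 40000 nM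

Compound 3 stands at the limit of > 40000 nM in this assay, at which 3 of the 3 values shown sit. The change leading to compound 4 `CCCCN(C)C(=O)CCCCOc1cc(OC)c(OC)c2oc(-c3ccc(OC)cc3)c(O)c(=O)c12`, still unmeasured, is (butyl(methyl)carbamoyl)methyl in place of (4-methylpiperazin-1-yl)carbonyl on a saturated chain carbon, three bonds along the chain from an oxygen on an aromatic ring. The chain thus becomes 4-(butyl(methyl)carbamoyl)butyl in place of 3-((4-methylpiperazin-1-yl)carbonyl)propyl.

The steps bearing on this amide change are a step that the two limits leave unreadable from compound 1 to compound 3 and a step that the two limits leave unreadable from compound 2 to compound 3. The third is a step that the two limits leave unreadable from compound 1 to compound 2. None gives a size to carry over, so no readable step in either direction is expected in this assay. The expected step is a number no higher from compound 3 to compound 4 (the limit leaves the size open). For compound 4 the estimate is 40000 nM, with an expected range of 15000 nM to 80000 nM.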

Compound 4, half-maximal inhibitory concentration: 10800 nM
Beside the measured number, compound 4's estimate is 3.7-fold (0.57 log units) above it; the measured number lies below the stated range.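

In this assay, with the butyl(methyl)amino amide kept and the chain going from 3-(butyl(methyl)carbamoyl)propyl to 4-(butyl(methyl)carbamoyl)butyl, the series shows an at least 3.7-fold lower number from compound 1 to compound 4 (0.56 log units; beyond the scatter). The same chain, with the amide also changed, gives an at least 3.7-fold lower number from compound 2 to compound 4 (0.56 log units; beyond the scatter) and an at least 3.7-fold lower number from compound 3 to compound 4 (0.56 log units; beyond the scatter), each size bounded by a limit. The earlier steps cannot be read, all three earlier entries being limits: the limit of > 40000 nM in this assay, at which 3 of the 4 values shown sit.

Going by these compounds, whether a longer chain lowers the number further remains open. So does whether a carboxylic acid at the chain end, or the 4-methylpiperazin-1-yl amide on the butyl chain, keeps this activity.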